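Swapping a Ring Ether for a Sulfonamide on a Nitrofuran Amide

The compounds below may be only part of what the source reports. "The series", "measured", "known", "first", "only" and "open" are said of these compounds alone.

Three compounds share a nitrofuran amide attached to a thiazole core, each with a different aryl group. Compound 1 `O=C(Nc1nc(-c2cccc(OC3CCCC3)c2)cs1)c1ccc([N+](=O)[O-])o1` carries a cyclopentyloxy-substituted phenyl ring. In an ADME assay on Vero cells (Chlorocebus sabaeus) for cytotoxicity, read by MTT assay, with a stated time of 72 h (on this read-out higher numbers stand for weaker inhibition and lower numbers for stronger inhibition), compound 1 gives 81100 nM, the highest of the two numbers available and therefore the weaker inhibitor of cell growth among them. Compound 2 `O=C(Nc1nc(-c2c(F)cc(F)cc2F)cs1)c1ccc([N+](=O)[O-])o1`, with a trifluorophenyl ring, gives 19900 nM in this assay, a difference beyond the usual scatter. Compound 3 `COc1cccc(-c2csc(NC(=O)c3ccc(N)o3)n2)c1`, whose nitro group is replaced by an amine, has only "not determined" (no result reported) recorded in this assay.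

Compound 4 `O=C(Nc1nc(-c2cccc(NS(=O)(=O)Cc3ccccc3)c2)cs1)c1ccc([N+](=O)[O-])o1` has not yet been measured. It differs from compound 1 in one place: (benzylsulfonyl)amino in place of cyclopentyloxy on an aromatic carbon. The group that leaves is cyclopentyloxy; the group that enters is (benzylsulfonyl)amino, sitting on an aromatic carbon of a six-membered aromatic ring of carbon only.

Among the compounds with values here, no measured pair shows a step of this kind, so the expectation rests on compound 1 alone. Compound 4 is expected to give 60000 nM in this assay, within a range from 20000 nM to 150000 nM. That estimate means a step of a 1.4-fold lower number from compound 1 to compound 4 (0.13 log units; within the scatter), expected to fall within the scatter rather than shift toxicity clearly in either direction.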

Compound 4, half-maximal inhibitory concentration in the Vero assay: 59300 nM
Compound 4: the middle estimate sits 1.0-fold (0.01 log units) above what was measured; low and high end bracket the measured number.
By their numbers in the Vero assay, from the lowest: compound 2; then compounds 4 and 1 (each within the scatter of the next).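

In the Vero assay, placing (benzylsulfonyl)amino on this aromatic carbon in place of cyclopentyloxy gives a 1.4-fold lower number from compound 1 to compound 4 (0.14 log units; within the scatter), so this larger group leaves that read-out without a clear shift. In a physicochemical assay for solubility, read by HPLC, with a stated time of 30 min (on this read-out lower numbers stand for lower solubility and higher numbers for higher solubility), the same swap does make a clear difference, and solubility rises: the measured solubility of compound 1, 0.027 ug/mL, and of compound 4, 0.48 ug/mL, an 18-fold higher number (1.25 log units; beyond the scatter) In the physicochemical assay, compound 1 gives 0.027 ug/mL and compound 4 gives 0.48 ug/mL. Together, the two read-outs part ways at this position, as one exchange of groups moves the solubility read-out beyond the scatter while the Vero assay stays within it.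

The compounds shown leave open which part of the entering group matters, the benzyl ring or the sulfonyl-bearing nitrogen. They also leave open how a simple amine or a carboxylic acid on the same aromatic carbon would behave in these two read-outs.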